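Piperidin-1-yl to ethyl(methyl)amino: estimate for compound 4

This account rests on a few compounds, and the source may have more. Where it says the series, first, only, none or still open, it means among the compounds named here.

Going by the values given here, in a functional assay on ECa-109 cells (Homo sapiens) for antiproliferative activity, with a stated time of 72 h (a lower number here means a stronger inhibitor, a higher number a weaker inhibitor), compound 2 (`COc1cc(OC)c(C(=O)/C=C/c2ccccc2Cl)c(O)c1CN1CCCCC1`) gives 2500 nM, the lowest number of the three measured so far. Compound 1 (`COc1cc(OC)c(C(=O)/C=C/c2ccccc2Cl)c(O)c1CN1CCCC1`) gives 6900 nM. Compound 3 (`COc1cc(O)c2c(=O)cc(-c3ccccc3Cl)oc2c1CN1CCCCC1`) gives 21500 nM. Both of these numbers lie higher than that of compound 2, beyond the scatter.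

The next compound to read is compound 4 (`CCN(C)Cc1c(OC)cc(OC)c(C(=O)/C=C/c2ccccc2Cl)c1O`). The change from compound 2 is ethyl(methyl)amino in place of piperidin-1-yl on a saturated chain carbon bound to an aromatic carbon, which puts ethyl(methyl)amino in place of piperidin-1-yl on a saturated chain carbon bound to an aromatic carbon.

Among the compounds with values here, only one measured step bears on this place: a 2.8-fold lower number from compound 1 to compound 2 (0.44 log units; beyond the scatter), a modest step with piperidin-1-yl in place of pyrrolidin-1-yl. Read in reverse, leaving piperidin-1-yl for that other ring gave the higher number. Within the data shown here, no compound with an open-chain amine has been measured, so this comparison is only a loose guide, and neither size nor direction is secure. In this assay, among the measured compounds shown here, a modest move to a higher number is expected, no larger than the step into compound 2 from compound 1. The estimated step is a 1.8-fold higher number from compound 2 to compound 4 (0.26 log units; within the scatter). Compound 4 is estimated at 4500 nM, with an expected range of 1800 nM to 11000 nM.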

Compound 4, half-maximal inhibitory concentration: 1400 nM
Compound 4: the middle estimate sits 3.2-fold (0.51 log units) above what was measured; the whole stated range lies above it.
By their numbers in this assay, from the lowest: compounds 4 and 2 (each within the scatter of the next); then compound 1; then compound 3.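

In this assay, on a saturated chain carbon bound to an aromatic carbon, the ring of piperidin-1-yl can give way to the open chain of ethyl(methyl)amino with no change that can be told apart, with a 1.8-fold lower number from compound 2 to compound 4 (0.25 log units; within the scatter) as the printed step, so among the compounds shown a ring at this place is not needed to reach the numbers of compound 2. Pyrrolidin-1-yl now stands apart from both of the other amines, since a 4.9-fold lower number from compound 1 to compound 4 (0.69 log units; beyond the scatter) joins the earlier 2.8-fold lower number from compound 1 to compound 2 (0.44 log units; beyond the scatter) as a second step beyond the scatter, and the difference in this series therefore does not follow simply from having a ring or an open chain. No measurement at hand gives a reason for these numbers.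

Going by these compounds, what a diethylamino, dimethylamino or morpholin-4-yl group would give at this place remains open, and with only three amines compared, no trend with amine size can be drawn. Also open is whether ethyl(methyl)amino would read level with piperidin-1-yl on the core of compound 3, where only piperidin-1-yl is shown, or whether that match holds only on the core shared by compound 2 and compound 4.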